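A few compounds are considered here, and "the series" means these few. Any claim that something is new, unique, unknown or untested is made for them only; others in the source may bear on it.

Measured so far:
Compound 1, `Cc1c(-c2cc(Cl)cc(Cl)c2)c(C(=O)O)nn1-c1nc(-c2cnn(C)c2)c(SC(C)C)s1`: "not active" (no number reported) in a functional assay on BJAB cells (Homo sapiens) for antiproliferative activity, with a stated time of 4 days; on this read-out lower numbers stand for an effect already at smaller amounts and higher numbers for an effect only at larger amounts of compound
Compound 2, `Cc1nn(-c2nc(-c3ccc(Cl)c(Cl)c3)c(SC(C)C)s2)c(C(=O)O)c1-c1cccc(F)c1`: 900 nM

Going by the values given here, of the two compounds with a result in this assay, compound 2 is the only one that gives a number; compound 1 is reported without a single number, so no comparison of size between them can be drawn. Compound 2 thus stands alone as the sole numerical reference point in this series.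

Compound 3, `Cc1nn(-c2nc(-c3ccc(Cl)c(Cl)c3)c(SC(C)C)s2)c(C(=O)O)c1-c1ccc(Cl)cc1`, is the next compound to be measured in this assay. It differs from compound 2 in one place: 4-chlorophenyl in place of 3-fluorophenyl on an aromatic carbon. Among the compounds with values here, no step between measured compounds of this kind exists in the data, so there is no precedent for how this assay responds to such an exchange.

With only the value of compound 2 to go on, the step from compound 2 to compound 3 is expected to stay within the usual scatter, with no clear direction, no change at the digits printed from compound 2 to compound 3 (within the scatter). Compound 3 is therefore estimated at 900 nM, with a range from 300 nM to 2700 nM.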

Compound 3, half-maximal effective concentration: 2500 nM
Compound 3: the middle estimate sits 2.8-fold (0.44 log units) below what was measured; measured number inside the range.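

In this assay, going by these compounds alone, the first step falls on the aryl group carried by the five-membered aromatic ring with 2 nitrogen, next to the ring atom that bears a carboxy group. Replacing 3-fluorophenyl with 4-chlorophenyl there gives a 2.8-fold higher number from compound 2 to compound 3 (0.44 log units; beyond the scatter), so this position responds to a change of substituted phenyl group, though only modestly, and the 4-chlorophenyl compound needs a larger amount for its effect. No measurement is available that bears on the reason for this step.

The exchange changes both the halogen and its place on the phenyl ring, so this single step cannot say which of the two matters, and 3-chlorophenyl or 4-fluorophenyl groups would be needed to separate them. Nor do the compounds shown tell how this position responds to an unsubstituted phenyl, to a group with a different atom in the ring such as pyridyl, or to a phenyl bearing an amine or a methoxy group.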